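The source may report more compounds than this note shows. Statements on the series, on what has been measured and on what is new or still open speak of the compounds shown alone.

Measured compounds:
compound 1 `CN(C(=O)c1cc2ccccc2n1C)c1ccccc1` — 21 nM
compound 2 `CN(CCCc1ccccc1)C(=O)c1cc2ccccc2[nH]1` — 63100 nM; 63000 nM (2 entries)
compound 3 `CN(Cc1ccccc1)Cc1cc2ccccc2[nH]1` — 700 nM

In an assay for inhibition of Amine oxidase [flavin-containing] B (Bos taurus), read by fluorescence (a higher number here means a weaker inhibitor, a lower number a stronger inhibitor), compound 1 gives 21 nM, the lowest of the two single numbers on record. Compound 2 is represented by several entries rather than a single number, as the record the several entries of compound 2 in this assay, 63100 nM; 63000 nM (2 entries) shows, and all of them sit far up the scale. Compound 3 gives 700 nM in this assay, the higher of the two single numbers; its gap to compound 1 lies beyond the usual scatter, but the two structures differ in more than one place, so the comparison says only what the two values show.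

The step to compound 4 `CN(Cc1ccccc1)Cc1cc2ccccc2n1C` is a single change: methyl in place of hydrogen on an aromatic nitrogen. No measured step of this kind exists among these compounds. Compound 1, the most potent measured compound, carries the same methyl on its aromatic nitrogen, but it also differs from compound 3 in the linker, so its value cannot be read as a step.

Compound 4 is therefore expected to give about 300 nM in this assay, within a range of 80 nM to 1500 nM. This estimate means a step of a 2.3-fold lower number from compound 3 to compound 4 (0.37 log units; beyond the scatter), expected to be a modest gain at most and possibly none beyond the scatter.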

Compound 4, inhibition constant: 9700 nM
Estimate against measurement, compound 4: 32-fold (1.51 log units) below; the measured number lies above the stated range.
By their numbers in this assay, from the lowest: compound 1; then compound 3; then compound 4.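

In this assay, methyl in place of hydrogen on the aromatic nitrogen gives a 14-fold higher number from compound 3 to compound 4 (1.14 log units; beyond the scatter). Among these compounds, this is the first measured step at this position, and it shows that, in the setting of compound 3, a single added methyl on this nitrogen, next to the ring atom that bears a large group, goes with a large loss of inhibition rather than a gain. Nothing on record bears on the cause of this step.

The compounds shown leave open whether an ethyl group or a longer chain on this nitrogen would read the same way as methyl. They also leave open what the same change does in a compound with a carbonyl in its linker, such as compound 1, for which no matching pair is shown.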